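Adding an Unsaturated Acid Chain to Compound 1

A few compounds are considered here, and "the series" means these few. Any claim that something is new, unique, unknown or untested is made for them only; others in the source may bear on it.

Compound 1 `CCCCCCCc1cccc2cncn12` carries a plain heptyl chain on its core and, in an assay for inhibition of Thromboxane-A synthase (Homo sapiens) (a lower number here means a stronger inhibitor, a higher number a weaker inhibitor), compound 1 gives 3300 nM. Going by the values given here, this places compound 1 level with compound 2 `O=C(O)CCCCc1ccc2cncn2c1`, which in this assay gives 3300 nM, the two together standing as the highest of the three numbers so far; the difference between them lies within the usual scatter. Compound 3 `O=C(O)CCCCc1cccn2cncc12`, which in this assay gives 390 nM, is the furthest from compound 1, its number being markedly lower and the gap lying beyond the scatter. Compounds 2 and 3 both carry a carboxylic-acid-bearing chain, and their two values differ by a wide margin, so the effect of such a chain evidently depends on the rest of the structure.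

Compound 4 `O=C(O)/C=C/CCCc1cccc2cncn12` differs from compound 1 by 2-carboxyethenyl in place of butyl on a saturated chain carbon, three bonds along the chain from an aromatic carbon. Among the compounds with values here, no step between measured compounds with this exact change is known. The values of compound 2 and compound 3 show that an acid-terminated chain on this kind of core can reach a number well below that of compound 1, though it need not. Compound 4 is therefore expected to be a somewhat stronger inhibitor than compound 1, with an estimated step in this assay of a 4.1-fold lower number from compound 1 to compound 4 (0.62 log units; beyond the scatter). The estimate for compound 4 is 800 nM, within a range from 150 nM to 4000 nM.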

Compound 4, half-maximal inhibitory concentration: 4.8 nM
The estimate for compound 4 lay 170-fold (2.22 log units) above the measured number, and the stated range ends above it.
By their numbers in this assay, from the lowest: compound 4; then compound 3; then compounds 1 and 2 (each within the scatter of the next).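

Going by these compounds alone, compound 4 gives the first step where only one place changes: with 2-carboxyethenyl in place of butyl, on a saturated chain carbon, three bonds along the chain from an aromatic carbon, this assay shows a 690-fold lower number from compound 1 to compound 4 (2.84 log units; beyond the scatter). The earlier compounds shown here showed only that acid-bearing chains could give different numbers on differently substituted cores, whereas this pair shows that, on the core of compound 1, the end of the chain at this place can by itself move the number by a large amount, well beyond the scatter. Nothing available here bears on the reason for a step of this size.

The change brings in the double bond and the carboxylic acid together, so the compounds shown leave open how much of the step belongs to either one. Also open, from the compounds shown here alone, is how the number would respond at this place to a saturated carboxylic acid chain, to a methyl ester or an amide in place of the acid, or to a longer chain between the core and the acid.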